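The compounds below may be only part of what the source reports. "The series", "measured", "known", "first", "only" and "open" are said of these compounds alone.

Values in a functional assay on MGC-803 cells (Homo sapiens) for inhibition, read by sulforhodamine B assay; on this read-out lower numbers stand for stronger inhibition and higher numbers for weaker inhibition:

- compound 1 `O=C1C=C(NCc2ccccc2)C(=O)c2c1nc1n2[C@H]2OC[C@@H](O)[C@H]2OC1`: 2670 nM
- compound 2 `O=C1C(Nc2ccccc2)=CC(=O)c2c1nc1n2[C@H]2OC[C@@H](O)[C@H]2OC1`: 1830 nM
- compound 3 `CCc1ccc(NC2=CC(=O)c3c(nc4n3[C@H]3OC[C@@H](O)[C@H]3OC4)C2=O)cc1`: 1110 nM

Compound 1 at 2670 nM lies within the scatter of compound 2 at 1830 nM. Compound 3 at 1110 nM shows a lower number than compound 1, and that gap is beyond the scatter.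

Compound 4 `O=C1C=C(Nc2ccccc2F)C(=O)c2c1nc1n2[C@H]2OC[C@@H](O)[C@H]2OC1` keeps the core of compound 1 and changes only the amine substituent: 2-fluorophenyl in place of benzyl on an amine nitrogen. In short, 2-fluorophenyl stands in place of benzyl on an amine nitrogen.

Among the compounds with values here, no measured step covers this exact change. The nearest evidence is indirect. Compound 2 carries a phenyl group on the amine and gives 1830 nM, but its core is an isomer of the core of compound 1. Within the data shown here, the only measured step, a 1.6-fold lower number from compound 2 to compound 3 (0.22 log units; within the scatter), adds ethyl on an aromatic carbon and stays within the scatter. Nothing measured here tests fluorine.

These data give no firm reason to expect a step beyond the scatter in this assay, though a slightly lower number seems more likely than a higher one. The estimated step is a 1.4-fold lower number from compound 1 to compound 4 (0.15 log units; within the scatter).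

For compound 4 the expected value is 1900 nM, with an estimated range from 800 nM to 4500 nM.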

Compound 4, half-maximal inhibitory concentration: 2080 nM
The estimate for compound 4 lay 1.1-fold (0.04 log units) below the measured number; the range from low to high includes it.
By their numbers in this assay, from the lowest: compounds 3, 2, 4 and 1 (each within the scatter of the next, the first and the last beyond it).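

In this assay, within the data shown here, the exchange of benzyl for 2-fluorophenyl on the amine nitrogen gives a 1.3-fold lower number from compound 1 to compound 4 (0.11 log units; within the scatter), the first direct reading of a change at this position on the core of compound 1. The aromatic ring now sits directly on the nitrogen and carries fluorine, yet the number stays within the scatter, so this position accepts the change without a measurable shift in this cell assay, and the heavy-atom count of the group is the same on both sides. No supporting measurement bears on this outcome, and none offers an account of it.

Among these compounds, the single step changes the link to the nitrogen and adds fluorine together, and plain phenyl on the core of compound 1 would be needed to read these two parts separately. Among the compounds shown here, also open is whether a longer chain such as phenethyl on the amine nitrogen, or a carboxylic acid on the aromatic ring, would move the number in this assay beyond the scatter, which the one step at this position does not do.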